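The source may hold more compounds than are shown below. What is called first, only, known or untested is meant among the compounds shown, and "the series" means these compounds.

Working notes on the series. Among the compounds with values here, in a functional assay on MIA PaCa-2 cells (Homo sapiens) for cytotoxicity, read by MTT assay, with a stated time of 72 h (a lower number here means that less compound is needed, a higher number that more compound is needed for the effect), compound 1 `O=C1/C(=C\c2ccc(O)cc2)c2ccccc2N1c1c(Cl)cccc1Cl` gives 2 ug/mL, the only actual number so far. Compound 2 `O=C1/C(=C\c2cccc(Oc3ccccc3)c2)c2ccccc2N1c1c(Cl)cccc1Cl` gives > 100 ug/mL, which is a limit and not a number. Compound 3 `O=C1/C(=C\c2ccccc2[N+](=O)[O-])c2ccccc2N1c1c(Cl)cccc1Cl` is next for testing. It keeps the core of compound 1 and carries 2-nitrophenyl in place of 4-hydroxyphenyl on a double-bonded chain carbon bound to a double-bonded ring carbon. Within the data shown here, no measured step isolates a single change, so the size of this one remains a judgement. Compound 2 also lacks the 4-hydroxyphenyl, and its > 100 ug/mL is the basis for expecting more compound to be needed, by a margin beyond the scatter in this assay. The expected step is a 6.0-fold higher number from compound 1 to compound 3 (0.78 log units; beyond the scatter). Compound 3 is estimated at 12 ug/mL, with an expected range of 3 ug/mL to 60 ug/mL.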

Compound 3, concentration for half-maximal effect: 5 ug/mL
The estimate for compound 3 lay 2.4-fold (0.38 log units) above the measured number, and the stated range covers the measured number.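

In this assay, within the data shown here, replacing 4-hydroxyphenyl with 2-nitrophenyl gives a first sized change at this position: a 2.5-fold higher number from compound 1 to compound 3 (0.40 log units; beyond the scatter). Compound 3 has no hydrogen-bond donor in the entering group and still gives 5 ug/mL, so in this pair a donor in this group is not a condition for a measured number. Compound 2 remains a limit and not a number, and no step to it can be read: the limit of > 100 ug/mL in this assay, at which 1 of the 3 values shown sits.

This single pair does not separate the identity of the nitro group from its place on the phenyl ring. It also leaves open whether an unsubstituted phenyl, or a phenyl carrying an amine or a carboxylic acid, would give a measured number on the same chain carbon.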